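A few compounds are considered here, and "the series" means these few. Any claim that something is new, unique, unknown or untested is made for them only; others in the source may bear on it.

Compound 1 `COc1ccc(C(=O)/C=C/c2cc3ccccc3[nH]c2=O)cc1`: 3300 nM
Compound 2 `O=C(/C=C/c1cc2ccccc2[nH]c1=O)c1ccc(O)cc1`: 6150 nM

Both numbers come from a functional assay on Hs-578T cells (Homo sapiens) for cytotoxicity, read by sulforhodamine B assay, with a stated time of 24 h; on this read-out higher numbers stand for weaker inhibition of growth and lower numbers for stronger inhibition of growth. Among the two measured compounds, compound 2 stands at the higher number, but its only neighbour is compound 1, and the step of a 1.9-fold higher number from compound 1 to compound 2 (0.27 log units; within the scatter) lies within the scatter, so the two cannot be ranked against each other. Compound 3 `O=C(/C=C/c1cc2ccccc2[nH]c1=O)c1ccc(Cl)cc1` has not yet been measured. It differs from compound 2 by chloro in place of hydroxy on an aromatic carbon, so that the 4-hydroxyphenyl of compound 2 becomes a 4-chlorophenyl. Among the compounds with values here, no measured step swaps these two groups, so nothing bears on it directly. Within the data shown here, the single measured step, which ran from compound 1 to compound 2, altered the substituent on that same oxygen and stayed within the scatter. The step of a 1.5-fold lower number from compound 2 to compound 3 (0.19 log units; within the scatter) is therefore expected to be small. Compound 3 is estimated at 4000 nM, in a range from 1500 nM to 12000 nM.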

Compound 3, concentration for 50% growth inhibition: 11100 nM
For compound 3 the middle estimate is 2.8-fold (0.44 log units) below the measured one; the range from low to high includes it.
By their numbers in this assay, from the lowest: compounds 1, 2 and 3 (each within the scatter of the next, the first and the last beyond it).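

In this assay, putting chloro in place of hydroxy gives a 1.8-fold higher number from compound 2 to compound 3 (0.26 log units; within the scatter), so this swap alone cannot rank the two compounds. Within the data shown here, putting chloro in place of methoxy at the same place, para to a large group, gives a 3.4-fold higher number from compound 1 to compound 3 (0.53 log units; beyond the scatter), the first step in this set to pass beyond the scatter, though only modestly: the group at this position can move growth inhibition a little, with the chloro of compound 3 weaker than the methoxy of compound 1. Nothing shown here explains that gap.

Compound 2 cannot be separated from either neighbour, so the place of hydroxy in this order stays unsettled. On these data alone, how an amine or a carboxylic acid at this position, or a longer chain on the oxygen, would read remains open.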